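Diethylamino in place of propylamino on the carbonyl carbon

A few compounds are considered here, and "the series" means these few. Any claim that something is new, unique, unknown or untested is made for them only; others in the source may bear on it.

In a functional assay on NTUB1 cells (Homo sapiens) for cytotoxicity, read by MTT assay, with a stated time of 72 h (a lower number here means a stronger inhibitor, a higher number a weaker inhibitor), compound 3 `CCCNC(=O)c1ccc(/C=C/C(=O)c2cc(OC)ccc2OC)cc1` gives 2260 nM, compound 2 `CNC(=O)c1ccc(/C=C/C(=O)c2cc(OC)ccc2OC)cc1` gives 2200 nM and compound 1 `COc1ccc(OC)c(C(=O)/C=C/c2ccc(C(=O)OC(C)C)cc2)c1` gives 4420 nM. All three lie within the scatter of one another, so compound 3 holds no distinct rank. Compound 4 `CCN(CC)C(=O)c1ccc(/C=C/C(=O)c2cc(OC)ccc2OC)cc1` differs from compound 3 by diethylamino in place of propylamino on a carbonyl carbon. For the measured compounds named here, three measured steps bear on this change: a 1.0-fold higher number from compound 2 to compound 3 (0.01 log units; within the scatter), a 2.0-fold lower number from compound 1 to compound 2 (0.30 log units; within the scatter) and a 2.0-fold lower number from compound 1 to compound 3 (0.29 log units; within the scatter). Going by the values given here, each stays within the scatter, although no measured compound carries diethylamino. The expected change is a 1.2-fold higher number from compound 3 to compound 4 (0.09 log units; within the scatter), which is no step beyond the scatter. For compound 4 the estimate is 2800 nM, with an expected range of 1300 nM to 6000 nM.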

Compound 4, half-maximal inhibitory concentration: 2690 nM
For compound 4 the middle estimate is 1.0-fold (0.02 log units) above the measured one; measured number inside the range.
By their numbers in this assay, from the lowest: compounds 2, 3, 4 and 1 (each within the scatter of the next).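

In this assay, compound 4 shows that this carbonyl carbon can carry an amide without the amide hydrogen, as diethylamino counts no hydrogen-bond donor, and the number moves only within the scatter: a 1.2-fold higher number from compound 3 to compound 4 (0.08 log units; within the scatter), and a 1.2-fold higher number from compound 2 to compound 4 (0.09 log units; within the scatter). Against the isopropoxy ester the step is also within the scatter, a 1.6-fold lower number from compound 1 to compound 4 (0.22 log units; within the scatter), so this change separates none of the compounds shown. No measurement offered here gives a cause for these readings. Still open, on these data alone, is whether a carboxylic acid, an unsubstituted amide or a longer chain on the nitrogen would move the number beyond the scatter.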